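This account rests on a few compounds, and the source may have more. Where it says the series, first, only, none or still open, it means among the compounds named here.

Measured compounds in a functional assay for activation of Alpha-1B adrenergic receptor (Homo sapiens), read by calcium flux; a higher number here means that more compound is needed for the effect, a lower number that less compound is needed:

Compound 1, `Cc1ccc(-c2ccccc2NCC2=NCCN2)o1`: in this assay compound 1 gives 46.8 nM.
Compound 2, `CO/N=C(\C)c1ccccc1NCC1=NCCN1`: for compound 2 this assay reports only a limit, < 5020 nM.
Compound 3, `CC/C(=N\OC)c1ccccc1NCC1=NCCN1`: for compound 3 this assay reports only a limit, < 100000 nM.

Compound 3 therefore stands at a limit rather than at a number, the one at the limit of < 100000 nM in this assay, at which 1 of the 3 values shown sits; of the other two values, one also sits at a limit, (the limit of < 5020 nM in this assay, at which 1 of the 3 values shown sits), and only compound 1 carries a measured number.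

Compound 4, `CO/N=C/c1ccccc1NCC1=NCCN1`, differs from compound 3 as follows: a group of 4 heavy atoms (2 carbon, 1 nitrogen, 1 oxygen; no ring) in place of a group of 6 heavy atoms (4 carbon, 1 nitrogen, 1 oxygen; no ring), on an aromatic carbon.

The measured steps that bear on this change are all unreadable. From compound 2 to compound 3 the step is a step that the two limits leave unreadable from compound 2 to compound 3; from compound 1 to compound 2 it is a step that the limit leaves unreadable from compound 1 to compound 2; from compound 1 to compound 3 it is a step that the limit leaves unreadable from compound 1 to compound 3. Among the measured compounds shown here, none gives a readable size, so no direction for the step to compound 4 can be drawn from them beyond the scatter, and compound 4 may again end at a limit. The expected step is a step that the limit leaves unreadable from compound 3 to compound 4. Compound 4 is estimated at 8000 nM, in the range 1500 nM to 50000 nM.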

Compound 4, half-maximal effective concentration: < 5020 nM
Compound 4 gave a limit, no number (the forecaster's own chance of this, stated with the estimate: 60%); middle value at least 1.5-fold (0.20 log units) away from the limit.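

In this assay compound 4 gives only a limit, < 5020 nM. Its steps from compound 1, compound 2 and compound 3 therefore cannot be read. The compounds shown leave open whether compound 2, compound 3 and compound 4 differ from one another at all, and by how much each differs from compound 1.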